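The compounds below may be only part of what the source reports. "The series", "measured", "known", "first", "only" and "open" are said of these compounds alone.

Three compounds share one core and have been measured in an ADME assay on the whole organism (strain CD-1) for metabolic stability, with Mus musculus as the target, at a dose of 3 mg/kg by the intravenous route; a higher number here means that the compound lasts longer, a lower number that the compound disappears faster:
compound 1, `CN(Cc1ccccc1OCCCCCC(=O)O)C(=O)c1ccc(-c2ccco2)cc1`, giving 1.7 h;
compound 2, `CC(CCCCOc1ccccc1CN(C)C(=O)c1ccc(-c2ccco2)cc1)C(=O)O`, giving 2.8 h;
compound 3, `C[C@@H](CCCOc1ccccc1CN(C)C(=O)c1ccc(-c2ccco2)cc1)CC(=O)O`, giving 2 h.

Compound 2 stands at the top of these three numbers, but only by a small margin: the step of a 1.6-fold higher number from compound 1 to compound 2 (0.22 log units; within the scatter) and the step of a 1.4-fold lower number from compound 2 to compound 3 (0.15 log units; within the scatter) both lie inside the scatter, so the three compounds cannot be told apart with confidence. All three carry a chain ending in a carboxylic acid, and the differences among them are a methyl group added or moved along that chain.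

Compound 4, `CN(Cc1ccccc1OCCC[C@@H]1C[C@H]1C(=O)O)C(=O)c1ccc(-c2ccco2)cc1`, carries the change (2-carboxycyclopropyl in place of 2-carboxypropyl on a saturated chain carbon, three bonds along the chain from an oxygen on an aromatic ring). This closes the branched end of the chain into a small ring while keeping the acid and the same count of heavy atoms.

Among the compounds with values here, the steps that bear on this change are those touching the same chain, a 1.6-fold higher number from compound 1 to compound 2 (0.22 log units; within the scatter) and a 1.4-fold lower number from compound 2 to compound 3 (0.15 log units; within the scatter), both within the scatter. Within the data shown here, nothing measured so far shows a ring in this place, so no step beyond the scatter is expected in this assay in either direction. Compound 4 is therefore expected to give about 2.5 h, within 1.2 h to 5 h, meaning an expected step of a 1.1-fold lower number from compound 2 to compound 4 (0.05 log units; within the scatter).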

Compound 4, half-life: 3.5 h
For compound 4 the middle estimate is 1.4-fold (0.15 log units) below the measured one, within the range that was stated.
By their numbers in this assay, from the lowest: compounds 1, 3, 2 and 4 (each within the scatter of the next, the first and the last beyond it).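

In this assay, placing the 2-carboxycyclopropyl group on this saturated chain carbon gives a compound that cannot be told apart from either methyl-bearing chain (a 1.3-fold higher number from compound 2 to compound 4 (0.10 log units; within the scatter); a 1.8-fold higher number from compound 3 to compound 4 (0.24 log units; within the scatter)), so closing the end of the chain into a three-membered ring, at the same count of heavy atoms, does not visibly cost anything in this assay. Against the unbranched chain of compound 1, however, the ring gives the first step in this set to clear the scatter (a 2.1-fold higher number from compound 1 to compound 4 (0.31 log units; beyond the scatter)), although the step is modest and neither methyl-bearing chain clears it on its own. Nothing available here accounts for this step, so the data show only that it exists.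

The compounds shown leave open whether the other arrangements of the two defined stereocentres of the ring would give a similar half-life, since compound 4 shows only one of them. They also leave open what happens with a primary amide in place of the carboxylic acid, or with a longer chain carrying the same ring.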